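This account rests on a few compounds, and the source may have more. Where it says the series, first, only, none or still open, it means among the compounds named here.

Measured so far:
compound 1 `C=C1C(=O)N(c2ccccc2)N(c2ccccc2)C1CC` — 14900 nM
compound 2 `C=C1C(=O)N(c2ccccc2)N(C)C1CC` — 576000 nM

In a functional assay on NALM-6 cells (Homo sapiens) for inhibition, read by MTT assay, with a stated time of 48 h (a lower number here means a stronger inhibitor, a higher number a weaker inhibitor), compound 1 gives the lowest of the two numbers; compound 2 stands a 39-fold higher number from compound 1 to compound 2 (1.59 log units; beyond the scatter) away, a move of methyl in place of phenyl on an amine nitrogen in a ring. Compound 3 `C=CCC1C(=C)C(=O)N(c2ccccc2)N1c1ccccc1` differs from compound 1 by vinyl in place of methyl on a saturated chain carbon bound to a saturated ring carbon. Within the data shown here, the one measured step concerns a different position and does not bear on this chain, so nothing measured points to a change beyond the scatter. Compound 3 is therefore expected near 15000 nM, within 5000 nM to 45000 nM, an expected step of a 1.0-fold higher number from compound 1 to compound 3 (0.00 log units; within the scatter).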

Compound 3, half-maximal inhibitory concentration: 740 nM
The estimate for compound 3 lay 20-fold (1.31 log units) above the measured number, outside the stated range (below it).
By their numbers in this assay, from the lowest: compound 3; then compound 1; then compound 2.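

Changing ethyl to allyl on a saturated chain carbon bound to a saturated ring carbon gives a 20-fold lower number from compound 1 to compound 3 (1.30 log units; beyond the scatter) in this assay. Among these compounds, the earlier pair varied only the amine nitrogen, so this is the first sign that the chain on the other side of the core also strongly affects the number. No available evidence explains this step. The compounds shown leave open whether the double bond or the added carbon matters, which a propyl chain in the same place could separate. On these data alone, how a longer chain or an amine there would read also remains open.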